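Bromo to methyl exchange on two cores

This account rests on a few compounds, and the source may have more. Where it says the series, first, only, none or still open, it means among the compounds named here.

Compound 1 `O=C1/C(=C/c2ccc(Br)cc2)Cc2ccccc21` and compound 2 `Cc1ccc(/C=C2\Cc3ccccc3C2=O)cc1` share one core, while compound 3 `O=C1CCCCC/C1=C\c1ccc(Br)cc1` and compound 4 `Cc1ccc(/C=C2\CCCCCC2=O)cc1` share another. The difference between the two cores is not broken down here. In a functional assay on CCRF-CEM cells (Homo sapiens) for inhibition (a higher number here means a weaker inhibitor, a lower number a stronger inhibitor), compound 1 gives 284000 nM and compound 2 gives 67100 nM, while compound 3 gives 42800 nM. The step of a 4.2-fold lower number from compound 1 to compound 2 (0.63 log units; beyond the scatter) follows the change (methyl in place of bromo on an aromatic carbon). Compound 3 differs from compound 4 by methyl in place of bromo on an aromatic carbon, the same kind of change, though here the place is para to a group of 9 heavy atoms rather than para to a large group. Compound 4 has not been measured. On the new core the expected step is a 3.6-fold lower number from compound 3 to compound 4 (0.55 log units; beyond the scatter). This expectation rests on the step of a 4.2-fold lower number from compound 1 to compound 2 (0.63 log units; beyond the scatter). Compound 4 is therefore estimated at 12000 nM, with a likely range from 4000 nM to 36000 nM.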

Compound 4, half-maximal inhibitory concentration: > 500000 nM
Compound 4 was reported as a limit; the forecaster's own chance of this, stated with the estimate: 5%; middle value at least 41-fold (1.61 log units) from the limit.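

In this assay, methyl in place of bromo on an aromatic carbon does not carry over from the core of compound 1 to the core of compound 3: the same change on two cores in this assay, a 4.2-fold lower number (0.63 log units; beyond the scatter) from compound 1 to compound 2 and an at least 11-fold higher number (1.06 log units; beyond the scatter) from compound 3 to compound 4, at least 49-fold (1.69 log units) apart, beyond the scatter of two such steps. On the second core the change gives an at least 11-fold higher number from compound 3 to compound 4 (1.06 log units; beyond the scatter), and the full size of this step stays unread, since its end point is a limit: the limit of > 500000 nM in this assay, at which 1 of the 4 values shown sits. With one pair on each core, the comparison shows that the step from the first core does not predict the second, but not which feature of the cores accounts for the difference.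

Still open, from the compounds shown here alone, is how chloro, methoxy or an amine at the same place would behave on each core. Going by these compounds, it is also open whether other cores would follow compound 1 or compound 3.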